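Changing the Drawn Double-Bond Geometry of Compound 2

A few compounds are considered here, and "the series" means these few. Any claim that something is new, unique, unknown or untested is made for them only; others in the source may bear on it.

Measured compounds:
compound 1, `CO/N=C(\CCN1CCN(c2ccccn2)CC1C)c1ccc(Cl)cc1` — 67.1 nM
compound 2, `CO/N=C(\CCN1CCC(c2ccccn2)CC1)c1ccc(Cl)cc1` — 134 nM

Both compounds were tested in an assay on HEK293 cells for displacement of a labelled ligand from D(4) dopamine receptor (Homo sapiens); on this read-out higher numbers stand for weaker inhibition and lower numbers for stronger inhibition. Compound 1 gives 67.1 nM, and compound 2 gives 134 nM. Compound 2 carries the higher of the two numbers, but the number of compound 1 stands close by and the gap between them lies within the scatter, so the two compounds are read as alike.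

Compound 3, `CO/N=C(/CCN1CCC(c2ccccn2)CC1)c1ccc(Cl)cc1`, keeps every atom and bond of compound 2 and differs only in drawn configuration: the two compounds have the same atoms and bonds and differ only in configuration as drawn: 1 of 1 stereo elements differ; a double bond is drawn E in compound 2 and Z in compound 3. For the measured compounds named here, no pair of measured compounds shows a change of this kind, so the data give no measured size for it. The expectation for compound 3 is a step of a 1.6-fold higher number from compound 2 to compound 3 (0.22 log units; within the scatter), leaning toward a higher number, with wide uncertainty. Compound 3 is therefore estimated at 220 nM, within a range from 50 nM to 900 nM.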

Compound 3, inhibition constant: 90 nM
Compound 3: middle estimate off by 2.4-fold (0.39 log units), on the high side, within the range that was stated.
By their numbers in this assay, from the lowest: compounds 1, 3 and 2 (each within the scatter of the next).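

In this assay, the step of a 1.5-fold lower number from compound 2 to compound 3 (0.17 log units; within the scatter) gives the first measured size for a change in the drawn configuration of this double bond. That step lies within the scatter, so compound 2 and compound 3 are read as alike, and in this one pair the double bond drawn E or Z makes no difference that can be told apart on this read-out. The comparison isolates that single change, since nothing else sets the two apart: the fact that compounds 2 and 3 differ only in the configuration as drawn

The compounds shown leave open whether the drawn geometry counts for as little on the core of compound 1. They also leave open whether this reading holds when a benzyloxy group replaces the methoxy group or a fluorine replaces the chlorine.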